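The compounds below may be only part of what the source reports. "The series", "measured", "known", "first", "only" and "open" are said of these compounds alone.

Compound 1 `CSc1nc2c(C)nsc2n1[C@H]1C[C@H](O)[C@@H](CO)O1` and compound 2 `Cc1nsc2c1nc(SCc1ccccc1)n2[C@H]1C[C@H](O)[C@@H](CO)O1` share one core, while compound 3 `CSc1nc2sncc2n1[C@H]1C[C@H](O)[C@@H](CO)O1` carries a second; how the two cores differ is not broken down here. In a functional assay on HFF cells (Homo sapiens) for inhibition (a higher number here means a weaker inhibitor, a lower number a stronger inhibitor), compound 1 gives only a limit, > 100000 nM. In this assay compound 2 likewise gives only a limit, > 100000 nM. The change between them, (phenyl in place of hydrogen on a saturated chain carbon bound to a sulfur), therefore yields a step that the two limits leave unreadable from compound 1 to compound 2, which cannot be read because both values sit at the limit of > 100000 nM in this assay, at which 2 of the 3 values shown sit. In this assay, within the data shown here, compound 3 gives 15000 nM, the only number in the set. Compound 4 `OC[C@H]1O[C@@H](n2c(SCc3ccccc3)nc3sncc32)C[C@@H]1O` is not yet measured; it arises from compound 3 by the same change, (phenyl in place of hydrogen on a saturated chain carbon bound to a sulfur). Since the earlier step is unreadable, the step from compound 3 to compound 4 is expected to be a 1.3-fold higher number from compound 3 to compound 4 (0.12 log units; within the scatter), resting on no measured size. Compound 4 is thus estimated at 20000 nM, between 3000 nM and 100000 nM.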

Compound 4, half-maximal inhibitory concentration: 2100 nM
Estimate against measurement, compound 4: 9.5-fold (0.98 log units) above; measured number outside the range, below it.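

On the core of compound 3, the change from methylsulfanyl to benzylsulfanyl gives in this assay a 7.1-fold lower number from compound 3 to compound 4 (0.85 log units; beyond the scatter). On the core shared by compound 1 and compound 2, the same change cannot be read, because both compounds sit at a limit and not at a number: the limit of > 100000 nM in this assay, at which 2 of the 4 values shown sit. The change therefore has one readable size, on one core, which shows that it can lower the number there but not whether that drop carries over to the other core.

The compounds shown leave open whether the phenyl ring itself matters or a longer chain on the sulfur would serve as well. An ethylsulfanyl group, or an amine on the phenyl ring, would remain to be tested on either core.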